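The compounds below may be only part of what the source reports. "The series", "measured", "known", "first", "only" and "open" are said of these compounds alone.

Measured so far in a physicochemical assay for lipophilicity; on this read-out higher numbers stand for higher lipophilicity and lower numbers for lower lipophilicity:

- compound 1 `C[C@H]1CC[C@@H]2[C@@H](OC(=O)[C@]23CC(c2ccc([N+](=O)[O-])cc2)=NO3)[C@]2(C)C(=O)C=C[C@@]12O`: 1.37
- compound 2 `Cc1cccc(C2=NO[C@]3(C2)C(=O)O[C@@H]2[C@H]3CC[C@H](C)[C@]3(O)C=CC(=O)[C@@]23C)c1`: 1.86
- compound 3 `C[C@H]1CC[C@@H]2[C@@H](OC(=O)[C@]23CC(c2ccc(Br)cc2)N(c2ccccc2)O3)[C@]2(C)C(=O)C=C[C@@]12O`: 4

Compound 3, at 4, stands highest of the three. Compound 2 at 1.86 and compound 1 at 1.37 both lie lower, and both gaps are beyond the scatter of repeated measurements.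

The next compound to be measured is compound 4 `C[C@H]1CC[C@@H]2[C@@H](OC(=O)[C@]23CC(c2ccc(Cl)cc2)N(c2ccccc2)O3)[C@]2(C)C(=O)C=C[C@@]12O`. It departs from compound 3 in a single place: chloro in place of bromo on an aromatic carbon. In words, this is chloro in place of bromo on an aromatic carbon, turning a 4-bromophenyl into a 4-chlorophenyl.

For the measured compounds named here, no measured step makes this same exchange, so the data offer no direct guide. Going by the values given here, the only measured step is a number 0.49 log units higher from compound 1 to compound 2 (beyond the scatter), and it bears on the question only loosely. It is modest, even though it replaces one whole substituted phenyl with another, and it sits on a carbon with a double bond to nitrogen. Against that, the smaller exchange of bromo for chloro is expected to shift this assay very little, perhaps slightly downward, and not beyond the scatter.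

The estimated change is a number 0.15 log units lower from compound 3 to compound 4 (within the scatter), which is expected to stay within the scatter. For compound 4, the expected value is 3.85, with an estimated range from 3.45 to 4.2.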

Compound 4, partition coefficient: 3.87
Compound 4: the middle estimate sits 0.02 log units below what was measured; the range from low to high includes it.
By their numbers in this assay, from the lowest: compound 1; then compound 2; then compounds 4 and 3 (each within the scatter of the next).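

In this assay the exchange of chloro for bromo on this aromatic carbon, para to a large group, gives a number 0.13 log units lower from compound 3 to compound 4 (within the scatter) and so leaves the two compounds indistinguishable on this read-out. For the compounds shown here, this is the first measured change at this position, and the first to alter a single atom on the phenyl ring rather than replace a whole substituted phenyl. Going by these compounds alone, the only earlier step, a number 0.49 log units higher from compound 1 to compound 2 (beyond the scatter) on a carbon with a double bond to nitrogen, lay beyond the scatter, and it differs from the new step in both place and kind of exchange, so the two say nothing about each other. Nothing available explains why 4-bromophenyl and 4-chlorophenyl read alike here.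

On these data alone, it remains open whether a quite different group at this aromatic carbon, such as an amine, a carboxylic acid or a longer chain, would stay as close to compound 3 as chloro does. As far as these compounds go, it is also open whether chloro in place of bromo would give so small a step on other versions of the shared core, such as those of compound 1 and compound 2.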